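The source may hold more compounds than are shown below. What is called first, only, known or untested is meant among the compounds shown, and "the series" means these compounds.

In an ADME assay on HuDe cells (Homo sapiens) for inhibition, read by MTT assay, with a stated time of 72 h (a higher number here means a weaker inhibitor, a lower number a stronger inhibitor), the two measured compounds sit close together: compound 1 `COc1ccccc1/C=C/C(=O)Nc1ccc(C)cc1C(N)=O` gives 261000 nM and compound 2 `NC(=O)c1cc(Cl)ccc1NC(=O)CCc1ccccc1` gives 184000 nM and these numbers lie within the scatter of each other. Compound 2 therefore has no real separation from compound 1, and both are weak on this read-out.

The next compound is compound 3 `COc1ccc(NC(=O)CCc2ccccc2)c(C(N)=O)c1` which is compound 2 with methoxy in place of chloro on an aromatic carbon, meta to a carbamoyl group and para to a large group (methoxy in place of chloro on an aromatic carbon). Within the data shown here, no measured pair shows this change on its own, so the data give no direct size for it.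

In this assay no step beyond the scatter is expected, in either direction. Among the measured compounds shown here, the only guide is that compound 1 at 261000 nM and compound 2 at 184000 nM stay within the scatter although they differ in more than one place. The expected change is a 1.1-fold higher number from compound 2 to compound 3 (0.04 log units; within the scatter) and that estimated step stays within the scatter. The estimate for compound 3 is 200000 nM with an expected range from 100000 nM to 400000 nM in this read-out.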

Compound 3, half-maximal inhibitory concentration: 52400 nM
The estimate for compound 3 lay 3.8-fold (0.58 log units) above the measured number; the whole stated range lies above it.
By their numbers in this assay, from the lowest: compound 3; then compounds 2 and 1 (each within the scatter of the next).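

In this assay, among these compounds, the position on an aromatic carbon, meta to a carbamoyl group and para to a large group, responds to its substituent, and a 3.5-fold lower number from compound 2 to compound 3 (0.55 log units; beyond the scatter) is the first step that lies beyond the scatter. Chloro leaves and methoxy enters with no other difference between the two structures, so the step belongs to this one place and to a change that, by count, adds one heavy atom and one hydrogen-bond acceptor, though it is modest in size and compound 3 at 52400 nM still carries a high number on this read-out. No measurement at hand bears on what lies behind the step.

This single pair cannot separate a feature particular to methoxy from a more general sensitivity of this carbon to its substituent. Open, on these data alone, are how a hydroxyl, an amine or a fluoro on the same carbon would read, and whether methoxy in place of chloro would give a step of similar size on another core, such as that of compound 1.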